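A Methyl Group Added to the Core of Compound 1

This account rests on a few compounds, and the source may have more. Where it says the series, first, only, none or still open, it means among the compounds named here.

Within the data shown here, compound 1 `N/C(=N\NC(=S)N1CCOCC1)c1ccccn1` is one of two compounds measured so far in a functional assay on HeLa cells (Homo sapiens) for cytotoxicity, read by MTT assay, with a stated time of 72 h, tested at 10 uM; on this read-out higher numbers stand for more inhibition of growth at the one concentration tested and lower numbers for less inhibition of growth. In this assay compound 1 gives 56.3%, the lower of the two numbers. Among the measured compounds shown here, the other measured compound, compound 2 `N/C(=N\NC(=S)N1CCN(c2ccccn2)CC1)c1ccc(F)cn1`, differs from compound 1 in more than one place, so no single step links the pair. In this assay compound 2 gives 80%, a number that lies beyond the scatter above that of compound 1.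

Compound 3 `Cc1ccnc(/C(N)=N/NC(=S)N2CCOCC2)c1` has not yet been measured. It differs from compound 1 by methyl in place of hydrogen on an aromatic carbon. For the measured compounds named here, no step between measured compounds shows what such a change does, and the two measured values cannot separate this change from the several others that set compound 2 apart from compound 1. On that basis the step is expected to be small, possible in either direction, and to stay within the scatter. The expected step of a number 1.7 percentage points higher from compound 1 to compound 3 (within the scatter) reflects this. Compound 3 is therefore estimated to give 58% in this assay, within a range from 42% to 74%.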

Compound 3, percent growth inhibition at one concentration: 49.1%
Beside the measured number, compound 3's estimate is 8.9 percentage points above it; the range from low to high includes it.
By their numbers in this assay, from the lowest: compounds 3 and 1 (each within the scatter of the next); then compound 2.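

In this assay, among these compounds, the change of hydrogen to methyl on an aromatic carbon, opposite the ring nitrogen, gives a number 7.2 percentage points lower from compound 1 to compound 3 (within the scatter) and is the first step between measured compounds that differ in one place. It shows that this one added carbon, at this place on the six-membered aromatic ring and with the rest of compound 1 unchanged, does not separate compound 3 from compound 1 on this read-out, so the position accepts a methyl group without a change that can be told from the scatter. Nothing measured on these compounds speaks to what lies behind this result.

From the compounds shown here alone, a single small group at a single place marks out little, however: whether a longer chain such as ethyl, an amine or a carboxylic acid on the same aromatic carbon would leave the number within the scatter or carry it beyond remains open. Also open, going by these compounds, is whether methyl on another aromatic carbon of the same ring would give a step of similar size, or whether the same change would read the same way on a compound other than compound 1.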